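Cyano for acetyl on the benzyl thioether

The source may report more compounds than this note shows. Statements on the series, on what has been measured and on what is new or still open speak of the compounds shown alone.

Measured compounds:
compound 1 `CC(C)n1c(SCc2ccccc2Cl)nc2cc(NC(=O)C3CC3)ccc21` with 6300 nM
compound 2 `COc1ccc(C(C)=O)cc1CSc1nc2cc(NC(=O)C3CC3)ccc2n1C(C)C` with 260 nM

The two compounds share a core and differ in the aromatic ring attached through the thioether. In an assay on isolated protein for inhibition of Gonadotropin-releasing hormone receptor (Homo sapiens) (a higher number here means a weaker inhibitor, a lower number a stronger inhibitor), compound 1 gives 6300 nM, while compound 2 gives 260 nM. Compound 2 therefore stands as the lower of the two numbers, and the gap between compound 1 and compound 2 lies well beyond the usual scatter of repeated measurements.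

The step to compound 3 `COc1ccc(C#N)cc1CSc1nc2cc(NC(=O)C3CC3)ccc2n1C(C)C` starts from compound 2. The change is cyano in place of acetyl on an aromatic carbon. Within the data shown here, no directly comparable pair among the measured compounds shows what such an exchange does in this assay, so any expectation rests on the position of compound 2 alone. One unfilled substituent is swapped for another of similar size, and the most likely outcome is a small shift, possibly none beyond the scatter, with a slight lean toward a higher number.

Compound 3 is expected to give 400 nM, with a range from 120 nM to 1300 nM. The estimated step of a 1.5-fold higher number from compound 2 to compound 3 (0.19 log units; within the scatter) is modest.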

Compound 3, half-maximal inhibitory concentration: 570 nM
Estimate against measurement, compound 3: 1.4-fold (0.15 log units) below; the measured number falls inside the stated range.
By their numbers in this assay, from the lowest: compound 2; then compound 3; then compound 1.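

In this assay, cyano in place of acetyl gives a 2.2-fold higher number from compound 2 to compound 3 (0.34 log units; beyond the scatter), so the substituent on this aromatic carbon, para to a methoxy group, affects the result, and the exchange of one hydrogen-bond acceptor for another does not leave the number unchanged. The step is modest, however, and the larger gain survives the loss of acetyl: replacing 2-chlorophenyl with 5-cyano-2-methoxyphenyl gives an 11-fold lower number from compound 1 to compound 3 (1.04 log units; beyond the scatter). The advantage over the 2-chlorophenyl ring of compound 1 therefore does not depend on acetyl alone, although acetyl gives the lower number of the two groups compared at this carbon. No measurement here bears on the reason for the difference between acetyl and cyano.

On these data alone, how a carboxamide, a methyl ester or a propanoyl group would behave at this aromatic carbon remains open, as does whether a longer ketone would keep the number of compound 2 or move it further. The compounds shown also leave open how much of the gain over compound 1 belongs to the methoxy group and how much to the substituent para to it, and an ethoxy group or a bare hydrogen in those places would bear on that question.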